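The source may hold more compounds than are shown below. What is called first, only, known or untested is meant among the compounds shown, and "the series" means these compounds.

In a functional assay on the whole organism (strain Wistar) for inhibition, with Rattus norvegicus as the target, read by paw edema, with stated times of 30 min and 60 min, at a dose of 50 mg/kg by the oral route (on this read-out higher numbers stand for more inhibition at the one dose given (going by the name of the read-out) and lower numbers for less inhibition), compound 1 `CCC(=O)N1N=C(c2ccc(F)cc2)CC1c1cn(-c2ccccc2)nc1-c1ccc(Cl)c(Cl)c1` gives 63.4%.
In this assay compound 2 `Cc1ccc(C2=NNC(c3cn(-c4ccccc4)nc3-c3ccc(Cl)c(Cl)c3)C2)cc1` gives 56.5%.
In this assay compound 3 `CC(=O)N1N=C(c2ccc(F)cc2)CC1c1cn(-c2ccccc2)nc1-c1ccc(Cl)c(Cl)c1` gives 59.5%.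

Compound 3 sits between the other two on these numbers, and all three lie within the usual scatter of one another. Within the data shown here, the only single-point step among them, a number 3.9 percentage points lower from compound 1 to compound 3 (within the scatter), is the change of methyl to hydrogen on the saturated chain carbon bound to the carbonyl carbon; it does not rise above the scatter.

The next compound, compound 4 `Fc1ccc(C2=NNC(c3cn(-c4ccccc4)nc3-c3ccc(Cl)c(Cl)c3)C2)cc1`, is reached from compound 3 by hydrogen in place of acetyl on an amine nitrogen in a ring. Among the measured compounds shown here, no measured step removes the acetyl from the ring nitrogen with the rest of the structure held, so the one step that is known, from compound 1 to compound 3, bears on the acyl chain only and not on its removal. Compound 2 carries a hydrogen on the same ring nitrogen but differs from compound 3 in two places, so only its value can be set beside that of compound 3, and the two lie within the scatter of each other.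

On this basis no step beyond the scatter is expected, and the expected step of a number 1.5 percentage points lower from compound 3 to compound 4 (within the scatter) is small. Compound 4 is estimated at 58%, in the range 48% to 68%.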

Compound 4, a percentage reported as inhibition, in the whole organism at one dose (the size of the read-out at that dose, not a potency): 40.5%
Estimate against measurement, compound 4: 17.5 percentage points above, and the stated range ends above it.
By their numbers in this assay, from the lowest: compound 4; then compounds 2, 3 and 1 (each within the scatter of the next).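

In this assay, the acyl group on the amine nitrogen in a ring now shows a change beyond the scatter: a number 19 percentage points lower from compound 3 to compound 4 (beyond the scatter), and likewise a number 22.9 percentage points lower from compound 1 to compound 4 (beyond the scatter), whereas the change within the acyl chain, a number 3.9 percentage points lower from compound 1 to compound 3 (within the scatter), did not leave the scatter. Hydrogen on that nitrogen does not go with a low number in every case, since compound 2 also carries it and gives 56.5%, so compound 2 goes against any simple rule that loss of the acyl group lowers the number; the aromatic substituent also counts here, with a number 16 percentage points lower from compound 2 to compound 4 (beyond the scatter) for fluoro in place of methyl on an aromatic carbon. Nothing at hand accounts for either step.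

The compounds shown leave open whether the fall on removing the acyl group depends on the fluoro substituent, as no compound here pairs an acetyl or propanoyl on the ring nitrogen with the methyl on the aromatic ring. Also open, as far as these compounds go, are other groups at the two sites, such as a butanoyl or benzoyl on the ring nitrogen and a chloro or methoxy on the aromatic carbon.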